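A few compounds are considered here, and "the series" means these few. Any claim that something is new, unique, unknown or untested is made for them only; others in the source may bear on it.

Measured compounds:
Compound 1 `Cc1ccc(-c2cc(COC3(C(F)(F)F)Oc4ccccc4C=C3C(=O)O)on2)cc1`: 51200 nM
Compound 2 `O=C(O)C1=Cc2ccccc2OC1(OCc1cc(-c2ccc([N+](=O)[O-])cc2)no1)C(F)(F)F`: > 150000 nM

Both numbers come from a functional assay on A549 cells (Homo sapiens) for inhibition, read by MTT assay, with a stated time of 24 h; on this read-out higher numbers stand for weaker inhibition and lower numbers for stronger inhibition. For compound 2 the value > 150000 nM is a limit of the assay rather than a number, and it sits at the limit of > 150000 nM in this assay, at which 1 of the 2 values shown sits. Compound 3 `O=C(O)C1=Cc2ccccc2OC1(OCc1cc(-c2ccc(F)cc2F)no1)C(F)(F)F` differs from compound 2 by 2,4-difluorophenyl in place of 4-nitrophenyl on an aromatic carbon. Within the data shown here, the only measured step, an at least 2.9-fold higher number from compound 1 to compound 2 (0.46 log units; beyond the scatter), swaps a different group at the same aromatic carbon, so it bears on this change only loosely. Because compound 1 gives 51200 nM, compound 3 is expected to land near it, an estimated step of an at least 2.1-fold lower number from compound 2 to compound 3 (0.33 log units; beyond the scatter). The estimate for compound 3 is 70000 nM, between 25000 nM and 200000 nM.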

Compound 3, half-maximal inhibitory concentration: > 150000 nM
Compound 3: no number, only a limit (the forecaster's own chance of this, stated with the estimate: 35%); at least 2.1-fold (0.33 log units) between middle value and limit.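

In this assay, 2,4-difluorophenyl in place of 4-methylphenyl gives an at least 2.9-fold higher number from compound 1 to compound 3 (0.46 log units; beyond the scatter), so a second group at this aromatic carbon, one with fluorine rather than nitro, also weakens inhibition. Compound 3, like compound 2, gives only a limit of the assay, so the step between them cannot be read: the limit of > 150000 nM in this assay, at which 2 of the 3 values shown sit.

As far as these compounds go, how far either compound lies past that limit stays open. So does whether plain phenyl or 4-ethylphenyl at this carbon would keep a measurable value like that of compound 1.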